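Aryl swap in a series sitting at its limit

This account rests on a few compounds, and the source may have more. Where it says the series, first, only, none or still open, it means among the compounds named here.

Measured in an ADME assay on MCF-10A cells (Homo sapiens) for inhibition, with a stated time of 48 h (a higher number here means a weaker inhibitor, a lower number a stronger inhibitor), so far:
compound 1 `O=C(Nc1ccc(OC(F)(F)F)cc1)N1CCC[C@H]1c1nc(-c2ccccc2)no1` gives > 50000 nM as a limit
compound 2 `O=C(Nc1ccc([N+](=O)[O-])cc1)N1CCC[C@H]1c1nc(-c2ccccc2)no1` gives > 50000 nM as a limit
compound 3 `O=C(Nc1ccc(Cl)cc1)N1CCC[C@H]1c1nc(-c2ccccc2F)no1` gives > 50000 nM as a limit

Compound 3 stands at > 50000 nM as a limit and not a number. For the measured compounds named here, the picture so far is the limit of > 50000 nM in this assay, at which 3 of the 3 values shown sit, and nothing finer, and no measured compound gives a readable value.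

Compound 4 `O=C(Nc1ccc(Cl)cc1)N1CCC[C@H]1c1nc(-c2cccc(Cl)c2)no1` carries 3-chlorophenyl in place of 2-fluorophenyl (3-chlorophenyl in place of 2-fluorophenyl on an aromatic carbon) on an aromatic carbon between two ring nitrogen atoms.

Going by the values given here, the only measured step is a step that the two limits leave unreadable from compound 1 to compound 2 and it concerns nitro in place of trifluoromethoxy elsewhere in the structure. Among the compounds with values here, it therefore offers no size to carry over, and no measured step changes the group that differs here. With only a limit as the starting point, no readable size or direction can be forecast in this assay for this change. The expected outcome is a number no higher from compound 3 to compound 4 (the limit leaves the size open) as an estimate only. Compound 4 is estimated at 50000 nM with an expected range from 15000 nM to 80000 nM and is expected to be reported most likely as a limit again.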

Compound 4, half-maximal inhibitory concentration: > 50000 nM
Compound 4 was reported as a limit; the forecaster's own chance of this, stated with the estimate: 85%; the middle value sits exactly at the limit.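

In this assay compound 4 gives > 50000 nM, a limit and not a number. Compound 3 also stands at a limit, so 3-chlorophenyl in place of 2-fluorophenyl yields no readable step between compound 3 and compound 4: the limit of > 50000 nM in this assay, at which 4 of the 4 values shown sit. The compounds shown leave open which group, if any, brings a readable value in this assay.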